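A few compounds are considered here, and "the series" means these few. Any claim that something is new, unique, unknown or untested is made for them only; others in the source may bear on it.

Measured compounds in a functional assay on PC-3 cells (Homo sapiens) for inhibition, read by colorimetric assay and MTT assay, with a stated time of 72 h; on this read-out lower numbers stand for stronger inhibition and higher numbers for weaker inhibition:
Compound 1, `C=CCCCCOc1ccccc1-c1cnc(OCCC=C)n1C`, 19000 nM
Compound 2, `C=CCCCCOc1ccccc1-c1cnc(OCCCCC=C)n1C`, 9000 nM
Compound 3, `C=CCCOc1ncc(-c2ccccc2OC)n1C`, 25000 nM

Compound 1 and compound 2 share one core and differ in a single place: but-3-en-1-yl in place of vinyl on a saturated chain carbon, two bonds along the chain from an oxygen on an aromatic ring. That change produced a 2.1-fold lower number from compound 1 to compound 2 (0.32 log units; beyond the scatter). Compound 3 carries a different core; the difference between the core of compound 1 and the core of compound 3 is hydrogen in place of pent-4-en-1-yl on a saturated chain carbon bound to an oxygen on an aromatic ring, and this gave a 1.3-fold higher number from compound 1 to compound 3 (0.12 log units; within the scatter), so the two cores sit close together in this assay.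

Compound 4, `C=CCCCCOc1ncc(-c2ccccc2OC)n1C`, has not yet been measured. It stands to compound 3 exactly as compound 2 stands to compound 1: but-3-en-1-yl in place of vinyl on a saturated chain carbon, two bonds along the chain from an oxygen on an aromatic ring. The place of the change is described in the same words in both pairs, so this is the same change made a second time; among the four compounds it occurs twice in all.

Since the two cores gave numbers within the usual scatter of each other, the step already seen is taken as the best guide. The step from compound 3 to compound 4 in this assay is expected to be about a 2.1-fold lower number from compound 3 to compound 4 (0.32 log units; beyond the scatter) because the same change on the core of compound 1 produced a 2.1-fold lower number from compound 1 to compound 2 (0.32 log units; beyond the scatter). On that basis compound 4 is estimated at 12000 nM, with a likely range from 6000 nM to 25000 nM. This rests on a single prior example, so the expectation is modest in confidence.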

Compound 4, half-maximal inhibitory concentration: 24000 nM
The estimate for compound 4 lay 2.0-fold (0.30 log units) below the measured number, within the range that was stated.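

In this assay, but-3-en-1-yl in place of vinyl on the core of compound 3 gave a 1.0-fold lower number from compound 3 to compound 4 (0.02 log units; within the scatter), so the step seen on the core of compound 1 did not appear as a step beyond the scatter here, while hydrogen in place of pent-4-en-1-yl, with the longer chain already on the other side of the molecule, gave a 2.7-fold higher number from compound 2 to compound 4 (0.43 log units; beyond the scatter). This does not show that the change behaves differently on the two cores, nor does it show that the change carries over from one to the other, as the two steps cannot be told apart: the same change on two cores in this assay, a 2.1-fold lower number (0.32 log units; beyond the scatter) from compound 1 to compound 2 and a 1.0-fold lower number (0.02 log units; within the scatter) from compound 3 to compound 4, 2.0-fold (0.31 log units) apart, within the scatter of two such steps The same caution applies to the difference between the cores, which was within the scatter in one pair and beyond it in the other, yet does not separate the two pairs: the same change on two cores in this assay, a 1.3-fold higher number (0.12 log units; within the scatter) from compound 1 to compound 3 and a 2.7-fold higher number (0.43 log units; beyond the scatter) from compound 2 to compound 4, 2.0-fold (0.31 log units) apart, within the scatter of two such steps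

On these data alone, whether an amine or a carboxylic acid in place of but-3-en-1-yl, or a chain longer than hex-5-en-1-yl, would move the number on either core remains open. As far as these compounds go, with only these two pairs in a single assay, it is also open whether such groups would make the two cores respond differently.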